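Series notes: methyl shift on the pyridine of compound 2

The source may report more compounds than this note shows. Statements on the series, on what has been measured and on what is new or still open speak of the compounds shown alone.

Two compounds of this series have been run in an ADME assay on the whole organism for pharmacokinetics, with Rattus norvegicus as the target, with a stated time of 6 h, at a dose of 10 mg/kg by the oral route; a lower number here means less compound in the circulation, a higher number more compound in the circulation at the dose given. Compound 1 `Cc1cn2c(-c3cn[nH]c3)cnc2c(Nc2cc(Cc3ncccn3)ns2)n1` gives 701 ng.h/mL. Compound 2 `Cc1ccc(Cc2cc(Nc3nc(C)cn4c(-c5cn[nH]c5)cnc34)sn2)nc1` gives 1370 ng.h/mL. Within the data shown here, the only step recorded, a 2.0-fold higher number from compound 1 to compound 2 (0.29 log units; within the scatter), stays within the scatter, so on the numbers at hand compound 2 stands alongside compound 1 rather than apart from it.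

Compound 3 `Cc1cccc(Cc2cc(Nc3nc(C)cn4c(-c5cn[nH]c5)cnc34)sn2)n1` is the next member. Its difference from compound 2 is 6-methylpyridin-2-yl in place of 5-methylpyridin-2-yl on a saturated chain carbon bound to an aromatic carbon; the change keeps the same atoms and rearranges only the methyl on the pyridine.

Among the measured compounds shown here, no measured step bears directly on this methyl shift. For the measured compounds named here, the one step available, from compound 1 to compound 2, swapped the whole six-membered ring and still stayed within the scatter. With nothing to argue for a move in either direction, the expectation is a step of no size beyond the scatter, a 1.1-fold lower number from compound 2 to compound 3 (0.02 log units; within the scatter), in this assay.

Compound 3 is therefore estimated at 1300 ng.h/mL in this assay, with a range from 500 ng.h/mL to 3200 ng.h/mL.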

Compound 3, area under the concentration-time curve: 3100 ng.h/mL
For compound 3 the middle estimate is 2.4-fold (0.38 log units) below the measured one, within the range that was stated.
By their numbers in this assay, from the lowest: compounds 1 and 2 (each within the scatter of the next); then compound 3.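

Moving only the methyl, with 6-methylpyridin-2-yl in place of 5-methylpyridin-2-yl on a saturated chain carbon bound to an aromatic carbon, gives in this assay a 2.3-fold higher number from compound 2 to compound 3 (0.35 log units; beyond the scatter), so this position responds to where the methyl sits on the pyridine even though the atoms stay the same. The replacement of pyrimidin-2-yl at the same place now has an outcome that depends on the methylpyridine chosen: a 2.0-fold higher number from compound 1 to compound 2 (0.29 log units; within the scatter) stays within the scatter, whereas 6-methylpyridin-2-yl gives a 4.4-fold higher number from compound 1 to compound 3 (0.65 log units; beyond the scatter). Nothing available on these compounds accounts for the higher number, so the change can be recorded only as a result in this one read-out.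

The compounds shown leave open whether the gain belongs to the methyl itself, since no ethyl, methoxy or amine stands in its place on the 6-methylpyridin-2-yl group. They also leave open whether this isomer pair would behave in the same way on any core other than the shared one, as the methyl shift is seen here in a single pair.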